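Notes on the anilinopyrimidinone series, step to compound 4

The source may hold more compounds than are shown below. What is called first, only, known or untested is meant among the compounds shown, and "the series" means these compounds.

Measured in a functional assay on K562 cells (Homo sapiens) for inhibition, read by trypan blue exclusion, with a stated time of 72 h; a higher number here means a weaker inhibitor, a lower number a stronger inhibitor:
compound 1 `Cc1ccc(S(=O)(=O)c2cc3cnc(Nc4ccc5[nH]ccc5c4)nc3n(C)c2=O)cc1` — 750 nM
compound 2 `Cc1ccc(S(=O)(=O)c2cc3cnc(Nc4cnc5[nH]ccc5c4)nc3n(C)c2=O)cc1` — 15000 nM
compound 3 `Cc1ccc(S(=O)(=O)c2cc3cnc(Nc4cnc5c(c4)CC(=O)N5)nc3n(C)c2=O)cc1` — 15000 nM

Compound 3 stands level with compound 2 at the digits shown, the two together giving the highest numbers of the three; its nearest neighbour is compound 2, with no change at the digits printed from compound 2 to compound 3 (within the scatter), and its furthest is compound 1, from which a 20-fold higher number from compound 1 to compound 3 (1.30 log units; beyond the scatter).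

Compound 4 `Cc1ccc(S(=O)(=O)c2cc3cnc(Nc4ccc5ncccc5c4)nc3n(C)c2=O)cc1` differs from compound 3 on the nitrogen on the aromatic ring as follows:
a group of 10 heavy atoms (9 carbon, 1 nitrogen; one six-membered aromatic ring of carbon only, one six-membered aromatic ring with 1 hetero atom) in place of a group of 10 heavy atoms (7 carbon, 2 nitrogen, 1 oxygen; one five-membered non-aromatic ring with 1 hetero atom, one six-membered aromatic ring with 1 hetero atom), on a nitrogen on an aromatic ring

Going by the values given here, the steps that bear on this are a 20-fold higher number from compound 1 to compound 2 (1.30 log units; beyond the scatter) and a 20-fold higher number from compound 1 to compound 3 (1.30 log units; beyond the scatter): both replace the ring system of compound 1, which carries a six-membered aromatic ring of carbon only, with one carrying a six-membered aromatic ring with 1 hetero atom, and both cost the same large amount. Compound 4 brings back a six-membered aromatic ring of carbon only at the attachment, as in compound 1, but it has no hydrogen-bond donor, which compounds 1, 2 and 3 all have. Among the compounds with values here, no measured step separates these two features, so the expectation is set between the two levels seen.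

Compound 4 is expected to fall at 3000 nM, in the range 700 nM to 15000 nM, which means the estimated step of a 5.0-fold lower number from compound 3 to compound 4 (0.70 log units; beyond the scatter).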

Compound 4, half-maximal inhibitory concentration: 10000 nM
The estimate for compound 4 lay 3.3-fold (0.52 log units) below the measured number; low and high end bracket the measured number.
By their numbers in this assay, from the lowest: compound 1; then compounds 4, 2 and 3 (each within the scatter of the next).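

In this assay, quinolin-6-yl in place of 1H-indol-5-yl on the nitrogen gives a 13-fold higher number from compound 1 to compound 4 (1.12 log units; beyond the scatter), so keeping a six-membered aromatic ring of carbon only at the attachment is not enough to hold the level of compound 1, something compounds 2 and 3 could not show. The other two steps, a 1.5-fold lower number from compound 2 to compound 4 (0.18 log units; within the scatter) and a 1.5-fold lower number from compound 3 to compound 4 (0.18 log units; within the scatter), both lie within the scatter, even though quinolin-6-yl has 0 hydrogen-bond donors and the group it replaces in compound 3 has 1, so of the four groups shown at this place only 1H-indol-5-yl stands apart from the rest. No measurement at hand accounts for any of these steps.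

The compounds shown leave open whether the large step from compound 1 comes from the change of the five-membered ring to a six-membered one or from the loss of the indole ring hydrogen on nitrogen, as the two go together in quinolin-6-yl. Also open, on these data alone, is whether another bicyclic group such as 1H-indazol-5-yl, or a phenyl ring carrying an amine, would stay near the number of compound 1 at this place.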